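Compound 3 to compound 4: exchanging the benzyl group

The source may hold more compounds than are shown below. What is called first, only, known or untested is meant among the compounds shown, and "the series" means these compounds.

Readings so far in a physicochemical assay for lipophilicity, using the shake flask method, at pH 7.4 (on this read-out lower numbers stand for lower lipophilicity and higher numbers for higher lipophilicity), by compound
Compound 1 `Cc1ccc(CNC(=O)c2nc(-c3ccc(F)cc3)n(CC[C@@H](O)C[C@@H](O)CC(=O)O)c2C2CC2)cc1` gives 0.45 as measured
Compound 2 `O=C(O)C[C@H](O)C[C@H](O)CCn1c(-c2ccc(F)cc2)nc(C(=O)NCc2cccc(F)c2)c1C1CC1` gives 0.51 as measured
Compound 3 `O=C(O)C[C@H](O)C[C@H](O)CCn1c(-c2ccc(F)cc2)nc(C(=O)NCc2ccc(F)cc2)c1C1CC1` gives 0.17 as measured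

Compound 3 stands at 0.17 in this small set. The reading runs a number 0.28 log units lower from compound 1 to compound 3 (within the scatter) and a number 0.34 log units lower from compound 2 to compound 3 (beyond the scatter) so only the second of these gaps stands clear of the noise.

Compound 4 `COc1ccccc1CNC(=O)c1nc(-c2ccc(F)cc2)n(CC[C@@H](O)C[C@@H](O)CC(=O)O)c1C1CC1` has not yet been measured. It differs from compound 3 by 2-methoxyphenyl in place of 4-fluorophenyl on a saturated chain carbon bound to an amide-type nitrogen and the same change can be read as 4-fluorobenzyl to 2-methoxybenzyl.

Among the measured compounds shown here, the steps that bear on this are the other exchanges of the aromatic group at the same place. One of them is small, at a number 0.06 log units higher from compound 1 to compound 2 (within the scatter) and the other is modest, at a number 0.34 log units lower from compound 2 to compound 3 (beyond the scatter) in the same read-out. For the measured compounds named here, no measured compound carries a methoxy group, so these steps give only a rough size for the change and little guidance on its direction. A small rise is expected, but nothing clearly beyond the scatter. The estimated step is a number 0.18 log units higher from compound 3 to compound 4 (within the scatter) on this reasoning.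

For compound 4 the estimated value is 0.35 with an expected range from 0 to 0.7 in this assay once measured.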

Compound 4, distribution coefficient: 0.16
The estimate for compound 4 lay 0.19 log units above the measured number; the measured number falls inside the stated range.
By their numbers in this assay, from the lowest: compounds 4, 3, 1 and 2 (each within the scatter of the next, the first and the last beyond it).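

In this assay the step is a number 0.01 log units lower from compound 3 to compound 4 (within the scatter) and so 2-methoxybenzyl and 4-fluorobenzyl cannot be told apart at this place, although the entering 2-methoxyphenyl counts one hydrogen-bond acceptor and the leaving 4-fluorophenyl none. The new group also gives a number 0.35 log units lower from compound 2 to compound 4 (beyond the scatter) and thus stands clear of the 3-fluorobenzyl of compound 2, as compound 3 does with a number 0.34 log units lower from compound 2 to compound 3 (beyond the scatter), while the reading of a number 0.29 log units lower from compound 1 to compound 4 (within the scatter) does not separate it from compound 1. Compound 1 lies within the scatter of all three other compounds. It goes against any clean split. Nothing measured alongside these readings accounts for why the two groups read alike.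

The compounds shown carry only fluoro, methyl and methoxy groups on the benzyl ring, so they leave open how this assay would respond to an amine or a carboxylic acid on that ring. They also do not tell whether a phenethyl group in place of the benzyl group would keep the readings this close.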